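The compounds below may be only part of what the source reports. "The series", "measured", "known", "first", "only" and "open" are said of these compounds alone.

Working notes on the bromophenyl series. Compound 1 `O=C(Nc1ccc(Br)cc1)N[C@H]1CC[C@H](Oc2ccc(F)cc2)CC1`, with 4-bromophenyl on an amide-type nitrogen, gives > 20000 nM in a functional assay on CRL2813 cells (Homo sapiens) for cytotoxicity, read by sulforhodamine B assay, with a stated time of 5 days (a higher number here means a weaker inhibitor, a lower number a stronger inhibitor), and this is a limit of the assay rather than a number. Within the data shown here, compound 2 `O=C(Nc1ccccc1Br)N[C@H]1CC[C@H](Oc2ccc(F)cc2)CC1` gives 7700 nM, the only actual number so far in this assay. Among the measured compounds shown here, the single measured step is an at least 2.5-fold lower number from compound 1 to compound 2 (0.41 log units; beyond the scatter), with 2-bromophenyl in place of 4-bromophenyl on an amide-type nitrogen. Its size is known only as a bound.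

Compound 3 `O=C(Nc1cccc(Br)c1)N[C@H]1CC[C@H](Oc2ccc(F)cc2)CC1` is not yet measured. It differs from compound 2 by 3-bromophenyl in place of 2-bromophenyl on an amide-type nitrogen, with the same atoms joined differently. For the measured compounds named here, only one step bears on this change, an at least 2.5-fold lower number from compound 1 to compound 2 (0.41 log units; beyond the scatter), and it is the sole exchange of one bromophenyl for another. On that basis, a move towards a higher number in this assay is expected, smaller than that step and possibly not beyond the scatter. The expected change is a 1.6-fold higher number from compound 2 to compound 3 (0.19 log units; within the scatter). For compound 3 the estimate is 12000 nM, with an expected range of 5000 nM to 28000 nM.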

Compound 3, half-maximal inhibitory concentration: 6200 nM
The estimate for compound 3 lay 1.9-fold (0.29 log units) above the measured number; measured number inside the range.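

In this assay, 3-bromophenyl in place of 2-bromophenyl on the amide-type nitrogen gives a 1.2-fold lower number from compound 2 to compound 3 (0.09 log units; within the scatter) and so leaves these two isomers indistinguishable in this read-out. The second new step, an at least 3.2-fold lower number from compound 1 to compound 3 (0.50 log units; beyond the scatter), shows that 3-bromophenyl, like 2-bromophenyl, stands apart from 4-bromophenyl, so among the three compounds shown only the 4-bromophenyl compound separates from the others, and compound 1 is no longer set against a single partner. Compound 1 carries a limit of the assay and not a number, so its separation from the other two compounds has a known direction but only a bound on its size: the limit of > 20000 nM in this assay, at which 1 of the 3 values shown sits.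

The compounds shown contain only bromine as the substituent on this phenyl ring, so it remains open whether a chlorophenyl, a methoxyphenyl or an unsubstituted phenyl group would follow the same order among its isomers. Also open, as far as these compounds go, is how the reading in this assay would respond to changes elsewhere on the shared core, such as an amine or a carboxylic acid in place of the fluorine on the phenoxy group.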